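From 3,5-dimethoxyphenyl to 4-acetylphenyl on the shared core

The source may report more compounds than this note shows. Statements on the series, on what has been measured and on what is new or still open speak of the compounds shown alone.

Values in a functional assay on HCT-116 cells (Homo sapiens) for antiproliferative activity, read by MTT assay, with a stated time of 72 h (a lower number here means a stronger inhibitor, a higher number a weaker inhibitor), stand as follows
- compound 1 `CC(=O)c1ccc(-c2cccc(NC(=O)CCc3ccc4c(c3)B(O)OC4)c2)cc1` gives 19000 nM
- compound 2 `COc1cccc(-c2cccc(NC(=O)CCc3cccc4c3COB4O)c2)c1` gives 46000 nM
- compound 3 `COc1cc(OC)cc(-c2cccc(NC(=O)CCc3cccc4c3COB4O)c2)c1` gives 50000 nM

Compound 3 at 50000 nM sits level with compound 2 at 46000 nM within the scatter, and compound 1 stands at a lower number, beyond the scatter. So compound 3 belongs to the weaker end of this small set.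

The next compound, compound 4 `CC(=O)c1ccc(-c2cccc(NC(=O)CCc3cccc4c3COB4O)c2)cc1`, has 4-acetylphenyl in place of 3,5-dimethoxyphenyl on an aromatic carbon of the shared core of compound 2 and compound 3.

For the measured compounds named here, only one measured step bears directly on this change. Methoxy in place of hydrogen on an aromatic carbon gave a 1.1-fold higher number from compound 2 to compound 3 (0.04 log units; within the scatter) in this assay and so moved nothing measurable. Going by the values given here, no measured step swaps in the acetyl group on this core. Among the compounds with values here, the only measured compound with 4-acetylphenyl is compound 1 at 19000 nM and its core differs, so it offers only a weak hint towards a lower number.

The expected change is small and towards a lower number, an estimated 1.7-fold lower number from compound 3 to compound 4 (0.22 log units; within the scatter) in this assay overall. Compound 4 is therefore estimated at 30000 nM with an expected range from 15000 nM to 60000 nM in this measurement.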

Compound 4, half-maximal inhibitory concentration: 48000 nM
For compound 4 the middle estimate is 1.6-fold (0.20 log units) below the measured one; low and high end bracket the measured number.
By their numbers in this assay, from the lowest: compound 1; then compounds 2, 4 and 3 (each within the scatter of the next).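

In this assay, replacing 3,5-dimethoxyphenyl with 4-acetylphenyl gives a 1.0-fold lower number from compound 3 to compound 4 (0.02 log units; within the scatter), and replacing 3-methoxyphenyl with it gives a 1.0-fold higher number from compound 2 to compound 4 (0.02 log units; within the scatter), so on the shared core these three aryl groups cannot be told apart at this position. The only gap beyond the scatter lies elsewhere, as a 2.5-fold higher number from compound 1 to compound 4 (0.40 log units; beyond the scatter): these two compounds both carry 4-acetylphenyl and differ only in the boron-containing group on the saturated chain carbon, two bonds along the chain from a carbonyl carbon, so the modest advantage of compound 1 goes with that group and does not follow the acetyl group onto the shared core. Nothing available here explains why the numbers fall this way.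

Still open is whether an amine or a carboxylic acid in the place of 4-acetylphenyl would move the number on the shared core, as the groups shown there all read alike. Also open, from the compounds shown here alone, is whether the 3-methoxyphenyl and 3,5-dimethoxyphenyl groups would give similar numbers on the core of compound 1, which appears here only with 4-acetylphenyl.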